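The source may hold more compounds than are shown below. What is called first, only, known or untested is meant among the compounds shown, and "the series" means these compounds.

Compound 3 `CS(=O)(=O)c1cccc(C(=O)Nc2ccc(Cl)c(-c3nnc4c(Cl)cccn34)c2)c1` has been tested in a functional assay on MDA-MB-231 cells (Homo sapiens) for antiproliferative activity, read by MTT assay, with stated times of 72 h and 4 h; a higher number here means a weaker inhibitor, a lower number a stronger inhibitor. In that test compound 3 gives > 100000 nM, which is a limit of the assay rather than a number. Two companions built on the same core tell the same story. Compound 1 `Cc1nc(C(=O)Nc2ccc(Cl)c(-c3nnc4c(Cl)cccn34)c2)cs1` gives > 100000 nM in this assay, again only a limit. Compound 2 `CS(=O)(=O)c1ccc(C(=O)Nc2ccc(Cl)c(-c3nnc4c(Cl)cccn34)c2)cc1` gives > 100000 nM in this assay, also a limit. All three therefore share (the limit of > 100000 nM in this assay, at which 3 of the 3 values shown sit), and between them there is a step that the two limits leave unreadable from compound 1 to compound 2, a step that the two limits leave unreadable from compound 1 to compound 3 and a step that the two limits leave unreadable from compound 2 to compound 3.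

The next compound, compound 4 `O=C(Nc1ccc(Cl)c(-c2nnc3c(Cl)cccn23)c1)c1ccccc1Cl`, has not yet been measured. It differs from compound 3 by 2-chlorophenyl in place of 3-(methylsulfonyl)phenyl on a carbonyl carbon. Among the measured compounds shown here, none of the measured steps involves a 2-chlorophenyl group, and every measured step is unreadable, so the data give no basis for expecting a shift in either direction beyond the scatter. For compound 4 the expected step is a number no higher from compound 3 to compound 4 (the limit leaves the size open). Compound 4 is estimated to give 100000 nM in this assay, expected to fall between 20000 nM and 400000 nM, quite possibly again as a limit.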

Compound 4, half-maximal inhibitory concentration: 59900 nM
Compound 4: middle estimate off by 1.7-fold (0.22 log units), on the high side, within the range that was stated.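

Among the four compounds, only compound 4 gives a number rather than a limit in this assay, and the other three stay at that limit: the limit of > 100000 nM in this assay, at which 3 of the 4 values shown sit.

At this place, on a carbonyl carbon, 2-chlorophenyl gives an at least 1.6-fold lower number from compound 3 to compound 4 (0.22 log units; that floor lies within the scatter), an at least 1.6-fold lower number from compound 2 to compound 4 (0.22 log units; that floor lies within the scatter) and an at least 1.6-fold lower number from compound 1 to compound 4 (0.22 log units; that floor lies within the scatter), while the steps among compound 1, compound 2 and compound 3 cannot be read. Each new step is only a floor lying within the scatter, so this change yields a readable value but no proven gain in strength.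

From the compounds shown here alone, how far the true gap extends remains open, since the three partners of compound 4 have no numbers. Also open, going by these compounds, is whether the chlorine of the 2-chlorophenyl group matters, which a plain phenyl group or a 2-bromophenyl group at this place would test.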